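The compounds below may be only part of what the source reports. "The series", "measured", "known", "first", "only" and "open" are said of these compounds alone.

Compound 1 `COc1cc(/C=C(/Sc2ccc(Br)cc2)C(=O)c2ccc(Br)cc2)ccc1O` gives 1000 nM in a functional assay on DU-145 cells (Homo sapiens) for inhibition, read by trypan blue exclusion, with a stated time of 96 h; on this read-out lower numbers stand for stronger inhibition of growth and higher numbers for weaker inhibition of growth.
Compound 2 `COc1cc(OC)c(/C=C(\C(=O)c2ccc(Br)cc2)S(=O)(=O)c2ccc(Br)cc2)c(OC)c1` reaches only a limit of the assay, > 100000 nM, in this assay.

Compound 1 stands as the only numbered value of the two shown in this assay; the other entry, for compound 2, is a limit and not a number, as the account of the limit of > 100000 nM in this assay, at which 1 of the 2 values shown sits, records. Among the compounds with values here, no step between two measured compounds is available, so no measured change gives a scale for what follows.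

Compound 3 `O=C(/C(=C\c1ccc(F)cc1Cl)Sc1ccc(Br)cc1)c1ccc(Br)cc1` is not yet measured. It differs from compound 1 in one place: 2-chloro-4-fluorophenyl in place of 4-hydroxy-3-methoxyphenyl on a double-bonded chain carbon bound to a double-bonded chain carbon. The group that leaves carries the only hydrogen-bond donor and the two hydrogen-bond acceptors of that ring, and the group that enters carries none; beyond that nothing is known about the effect of this change on the shared core.

The expectation for compound 3 in this assay is a step of a 3.0-fold higher number from compound 1 to compound 3 (0.48 log units; beyond the scatter), a moderate weakening of growth inhibition that may reach beyond the scatter. Compound 3 is accordingly estimated at 3000 nM, with a range from 700 nM to 20000 nM.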

Compound 3, concentration for 50% growth inhibition: 1000 nM
Beside the measured number, compound 3's estimate is 3.0-fold (0.48 log units) above it; the measured number falls inside the stated range.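

In this assay, within the data shown here, placing 2-chloro-4-fluorophenyl in place of 4-hydroxy-3-methoxyphenyl on a double-bonded chain carbon bound to a double-bonded chain carbon gives no change at the digits printed from compound 1 to compound 3 (within the scatter), the first readable step at this position. The group that enters carries no hydrogen-bond donor or acceptor, so, for this pair, growth inhibition does not depend on keeping the donor and acceptors of the group that leaves. The compounds shown do not explain why the two values match, and no measurement bears on the cause.

On these data alone, the chlorine and fluorine enter together, and the hydroxy and methoxy groups leave together, so the contribution of each remains open, as does the outcome with a different group at this place, such as an amine, a carboxylic acid or a longer chain. As far as these compounds go, compound 2 differs from compound 1 and from compound 3 in more than one place, so the effect of a sulfonyl group in place of the sulfur link alone also remains open.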